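A few compounds are considered here, and "the series" means these few. Any claim that something is new, unique, unknown or untested is made for them only; others in the source may bear on it.

In an ADME assay for pharmacokinetics, read by HPLC, in phosphate buffer, with a stated time of 72 h, at pH 7.4, tested at 250 uM (on this read-out lower numbers stand for a shorter-lived compound and higher numbers for a longer-lived compound), compound 1 `C=CC(=O)Nc1cc(C(F)(F)F)cc(C(F)(F)F)c1` gives 4.2 h. Compound 2 `O=C1C=CC(=O)N1c1cc(C(F)(F)F)cc(C(F)(F)F)c1` gives < 0.017 h in this assay, a limit of the assay rather than a number. Compound 3 `C=Cc1cc(C(F)(F)F)cc(C(F)(F)F)c1` gives > 50 h, again only a limit of the assay.

Among the three values shown, compound 3 sits at the long-lived end, though its exact number is not known. Compound 4 `O=C(CBr)c1cc(C(F)(F)F)cc(C(F)(F)F)c1` differs from it by (bromomethyl)carbonyl in place of vinyl on an aromatic carbon. Going by the values given here, two measured steps touch this same position: an at least 11-fold higher number from compound 1 to compound 3 (1.07 log units; beyond the scatter) and an at least 2900-fold higher number from compound 2 to compound 3 (3.46 log units; beyond the scatter). In both, the group carrying a carbonyl gave the shorter-lived compound, and both were large. A large fall is therefore expected, that is an at least 16-fold lower number from compound 3 to compound 4 (1.22 log units; beyond the scatter). Compound 4 is estimated at 3 h, with a range from 0.3 h to 30 h.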

Compound 4, half-life: < 0.017 h
Compound 4: no number, only a limit (the forecaster's own chance of this, stated with the estimate: 15%); middle value at least 170-fold (2.24 log units) from the limit.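

A carbonyl group with no nitrogen on the aromatic carbon also gives a short-lived compound, and the falls are large: an at least 2900-fold lower number from compound 3 to compound 4 (3.46 log units; beyond the scatter), and an at least 240-fold lower number from compound 1 to compound 4 (2.39 log units; beyond the scatter). So (bromomethyl)carbonyl, with no ring, reaches the same short end of this assay as the ring of compound 2. Compound 4 gives only a limit of the assay, shared with compound 2, and the step between them cannot be read: the limit of < 0.017 h in this assay, at which 2 of the 4 values shown sit.

Going by these compounds, whether the fall goes with the bromine or with the carbonyl stays open. An acetyl group, the same group without the bromine, would separate the two.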